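Aryl group change from compound 3 to compound 4

This account rests on a few compounds, and the source may have more. Where it says the series, first, only, none or still open, it means among the compounds named here.

Measured in an ADME assay on DU-145 cells (Homo sapiens) for cytotoxicity, read by MTT assay, with a stated time of 72 h; on this read-out lower numbers stand for stronger inhibition and higher numbers for weaker inhibition:
- Compound 1 `COc1ccc(C2=C(c3cc(OC)c(OC)c(OC)c3)C(=O)CC2O[SiH2]C(C)(C)C)cc1OC` gives > 100 ug/mL (a limit)
- Compound 2 `COCOc1cc(C2=C(c3cc(OC)c(OC)c(OC)c3)C(=O)CC2O[SiH2]C(C)(C)C)ccc1OC` gives 34 ug/mL
- Compound 3 `COc1cc(C2=C(c3cc(C)c(OC)c(C)c3)C(O[SiH2]C(C)(C)C)CC2=O)cc(OC)c1OC` gives > 100 ug/mL (a limit)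

Compound 3 has no number, only the limit > 100 ug/mL. This is the limit of > 100 ug/mL in this assay, at which 2 of the 3 values shown sit.

The next compound is compound 4 `COc1ccc(C2=C(c3cc(OC)c(OC)c(OC)c3)C(=O)CC2O[SiH2]C(C)(C)C)cc1O`. The change is 3-hydroxy-4-methoxyphenyl in place of 4-methoxy-3,5-dimethylphenyl on a double-bonded ring carbon, with 3-hydroxy-4-methoxyphenyl in place of 4-methoxy-3,5-dimethylphenyl on a double-bonded ring carbon.

The closest measured step is an at least 2.9-fold higher number from compound 2 to compound 3 (0.46 log units; beyond the scatter), which also removes the 4-methoxy-3,5-dimethylphenyl side of the comparison from a compound with a measured number. The step of an at least 2.9-fold lower number from compound 1 to compound 2 (0.46 log units; beyond the scatter) shows that this assay responds to a change on this aryl group. The step that the two limits leave unreadable from compound 1 to compound 3 gives no size.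

Compound 4 goes against compound 3 in the same direction as compound 2 does, so a lower number of at least modest size is expected, with a real chance of staying at the limit. The expected step is an at least 4.0-fold lower number from compound 3 to compound 4 (0.60 log units; beyond the scatter). For compound 4 the estimated value is 25 ug/mL, with an expected range from 5 ug/mL to 100 ug/mL.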

Compound 4, half-maximal inhibitory concentration: 75 ug/mL
Estimate against measurement, compound 4: 3.0-fold (0.48 log units) below, within the range that was stated.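

On the oxygen on the aromatic ring, hydrogen does not match methoxymethyl in this assay: a 2.2-fold higher number from compound 2 to compound 4 (0.34 log units; beyond the scatter). Against methyl on that oxygen the result is an at least 1.3-fold lower number from compound 1 to compound 4 (0.12 log units; that floor lies within the scatter), and against 4-methoxy-3,5-dimethylphenyl it is an at least 1.3-fold lower number from compound 3 to compound 4 (0.12 log units; that floor lies within the scatter), so compound 4 may improve on either, but neither gain can be sized. Compound 1 and compound 3 each carry a limit and not a number, which is what leaves those two steps open-ended: the limit of > 100 ug/mL in this assay, at which 2 of the 4 values shown sit.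

Open, going by these compounds, is whether the methoxymethyl result at this oxygen extends to other groups there, such as an ethyl group, a longer ether chain or a chain ending in a carboxylic acid. Also open, on these data alone, is how an amine in place of the hydroxy group on the 3-hydroxy-4-methoxyphenyl ring would read in this assay.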